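A few compounds are considered here, and "the series" means these few. Any claim that something is new, unique, unknown or untested is made for them only; others in the source may bear on it.

Three compounds share one core and were tested in an assay on membranes from brain for displacement of a labelled ligand from Sigma non-opioid intracellular receptor 1 (Cavia porcellus), read by scintillation counting, with a stated time of 120 min; on this read-out higher numbers stand for weaker inhibition and lower numbers for stronger inhibition. Compound 1 `Cc1ccc(-c2scc3c2CCOC32CCN(Cc3ccccc3)CC2)cc1` gives 3.6 nM, compound 2 `O=[N+]([O-])c1ccc(-c2scc3c2CCOC32CCN(Cc3ccccc3)CC2)cc1` gives 1.7 nM, and compound 3 `COC1Cc2c(csc2-c2cccc3ccccc23)C2(CCN(Cc3ccccc3)CC2)O1` gives 5 nM. Of these three numbers, that of compound 3 is the highest, but its gap to compound 1 lies within the scatter, and only its gap to compound 2 lies beyond it. Among the compounds with values here, the single measured step, a 2.1-fold lower number from compound 1 to compound 2 (0.33 log units; beyond the scatter), was modest.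

Compound 4 `COC1Cc2c(csc2-c2cccnc2)C2(CCN(Cc3ccccc3)CC2)O1` differs from compound 3 by pyridin-3-yl in place of naphthalen-1-yl on an aromatic carbon. Within the data shown here, the measured step concerns a substituent on the phenyl ring of compound 1 and compound 2, not the aryl ring itself, so it does not bear directly on this change; no measured step exchanges the whole aryl group. Given the small spread across compound 1, compound 2 and compound 3, a move of only modest size is expected. Compound 4 is estimated to give 12 nM, with a range from 4 nM to 40 nM. This expected shift, a 2.4-fold higher number from compound 3 to compound 4 (0.38 log units; beyond the scatter), is toward a higher number, but only slightly beyond the scatter.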

Compound 4, inhibition constant: 2.2 nM
For compound 4 the middle estimate is 5.5-fold (0.74 log units) above the measured one, and the stated range ends above it.
By their numbers in this assay, from the lowest: compounds 2, 4, 1 and 3 (each within the scatter of the next, the first and the last beyond it).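

Within the data shown here, at this aromatic carbon next to the ring sulfur, the earlier compounds varied only a substituent on a phenyl ring, whereas here the whole aryl group is exchanged, and pyridin-3-yl in place of naphthalen-1-yl gives (a 2.3-fold lower number from compound 3 to compound 4 (0.36 log units; beyond the scatter)). Binding in this assay is therefore not lost when the group shrinks from 10 heavy atoms to 6 and takes on a ring nitrogen with 1 hydrogen-bond acceptor. No measurement on hand explains the shift.

On these data alone, this single step changes size and ring atoms together, so their separate contributions remain open; a plain phenyl group on the core of compound 3 would help to separate them. Also open, as far as these compounds go, is how this position responds to a group that is not an aromatic ring, such as cyclohexyl or a short chain ending in an amine.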